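The compounds below may be only part of what the source reports. "The series", "measured", "known", "first", "only" and "open" are said of these compounds alone.

Series notes. Compound 1, `CC(C)(O)c1cn(-c2ccc(-c3cccc(S(C)(=O)=O)c3)cc2)c(C(C)(C)c2ccccc2Cl)n1`, gives 8.9 h in an ADME assay on the whole organism (Macaca fascicularis) for metabolic stability, read by LC-MS, using cassette dosing, at a dose of 0.2 mg/kg by the intravenous route; a lower number here means that the compound disappears faster, a higher number that the compound lasts longer. Going by the values given here, compound 2, `CC(C)(O)c1cn(-c2ccc(-c3cc(F)c(CO)c(S(C)(=O)=O)c3)cc2)c(C(C)(C)c2ccccc2Cl)n1`, gives 5.6 h in this assay; the two figures lie within the usual scatter of each other, so no order between compound 1 and compound 2 is claimed, and compound 2 differs from compound 1 in more than one place, so no single step is drawn from it.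

Compound 3, `CC(O)c1ccc(-c2ccc(-n3cc(C(C)(C)O)nc3C(C)(C)c3ccccc3Cl)cc2)cc1S(C)(=O)=O`, is not yet measured. It differs from compound 1 by 1-hydroxyethyl in place of hydrogen on an aromatic carbon. Among the compounds with values here, only two compounds are in hand, and none of them tells what this single change does on its own, so the direction of the step is uncertain. Compound 2 carries a hydroxymethyl on the same ring and stays within the scatter of compound 1, which is the nearest guide.

Compound 3 is therefore expected to stay within the scatter, with the step of a 1.4-fold lower number from compound 1 to compound 3 (0.14 log units; within the scatter) small and without a clear direction. The expected half-life of compound 3 in this assay is 6.5 h, with a range from 3.5 h to 12 h.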

Compound 3, half-life: 5.5 h
The estimate for compound 3 lay 1.2-fold (0.07 log units) above the measured number; measured number inside the range.
By their numbers in this assay, from the lowest: compounds 3, 2 and 1 (each within the scatter of the next).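

Going by these compounds alone, the 1-hydroxyethyl in place of hydrogen, ortho to a methylsulfonyl group and para to a large group, gives the first single-place reading at this aromatic carbon: in this assay the step is a 1.6-fold lower number from compound 1 to compound 3 (0.21 log units; within the scatter). This aromatic carbon therefore takes the 1-hydroxyethyl group with no change in half-life that can be told from the scatter, and no direction can be assigned to the step. Nothing measured on these compounds bears on the reason for this result.

From the compounds shown here alone, whether an amine, a carboxylic acid or a longer chain on this carbon would move the half-life beyond the scatter remains open. Also open, going by these compounds, is how the 1-hydroxyethyl group would read on another carbon of the same ring.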